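Notes on an aryl exchange in the series

The source may hold more compounds than are shown below. What is called first, only, known or untested is meant among the compounds shown, and "the series" means these compounds.

Compound 1 `O=[N+]([O-])c1ccc(CN2CCC(n3cc(CC(OCc4cc(-c5ccccc5)no4)c4ccc(Br)cc4)nn3)CC2)cc1` in a functional assay on HCT-116 cells (Homo sapiens) for cytotoxicity, with a stated time of 48 h (on this read-out lower numbers stand for stronger inhibition and higher numbers for weaker inhibition), gives > 25000 nM, which is a limit of the assay and not a number. Compound 2 `COc1cccc(-c2cc(COC(Cc3cn(C4CCN(Cc5ccc([N+](=O)[O-])cc5)CC4)nn3)c3ccc(Br)cc3)on2)c1` in this assay gives > 25000 nM, again only a limit. Among the compounds with values here, the one measured step, a step that the two limits leave unreadable from compound 1 to compound 2, thus cannot be read, since both values sit at the limit of > 25000 nM in this assay, at which 2 of the 2 values shown sit. Compound 3 `O=[N+]([O-])c1ccc(CN2CCC(n3cc(CC(OCc4cc(-c5ccccc5F)no4)c4ccc(Br)cc4)nn3)CC2)cc1` carries 2-fluorophenyl in place of 3-methoxyphenyl on an aromatic carbon. No readable step bears on this exchange, and compound 2 stands only at a limit. Compound 3 is therefore expected to stay at the limit, with an estimated step that the limit leaves unreadable from compound 2 to compound 3. The estimate for compound 3 is 30000 nM, in the range 15000 nM to 80000 nM.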

Compound 3, half-maximal inhibitory concentration: 9000 nM
For compound 3 the middle estimate is 3.3-fold (0.52 log units) above the measured one, and the stated range ends above it.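

In this assay, the aryl group on the aromatic carbon next to the ring nitrogen turns out to affect the read-out, with an at least 2.7-fold lower number from compound 2 to compound 3 (0.44 log units; beyond the scatter). Fluoro in place of hydrogen on the phenyl also counts, with an at least 2.7-fold lower number from compound 1 to compound 3 (0.44 log units; beyond the scatter). Both steps are only bounds and the step between compound 1 and compound 2 cannot be read, since those two compounds sit at a limit: the limit of > 25000 nM in this assay, at which 2 of the 3 values shown sit.

As far as these compounds go, whether the step depends on where fluoro sits on the phenyl remains open. Also open, from the compounds shown here alone, is what an amine or a carboxylic acid on that phenyl would give.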